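The source may report more compounds than this note shows. Statements on the series, on what has been measured and on what is new or still open speak of the compounds shown alone.

Measured so far:
compound 1, `CCc1ccc(-c2nc3c(c(C)nn3-c3ccccc3)c(-c3ccccc3[N+](=O)[O-])c2C#N)cc1`, 1200 nM in a physicochemical assay for solubility, read by spectrophotometry, in phosphate buffer, with a stated time of 18 h, at pH 7.4; a higher number here means a more soluble compound, a lower number a less soluble compound
compound 2, `CCc1ccc(-c2nc3c(c(C)nn3-c3ccccc3)c(-c3ccccc3Cl)c2C#N)cc1`, 1700 nM

Compound 2 holds the higher of the two numbers, but compound 1 sits only a 1.4-fold higher number from compound 1 to compound 2 (0.15 log units; within the scatter) away, a gap within the scatter, so the two compounds cannot be told apart in this assay. Compound 3, `CCc1ccc(-c2nc3c(c(C)nn3-c3ccccc3)c(-c3ccc(O)cc3)c2C#N)cc1`, has not yet been measured in this assay. Its change from compound 2 is 4-hydroxyphenyl in place of 2-chlorophenyl on an aromatic carbon. For the measured compounds named here, the single measured step, a 1.4-fold higher number from compound 1 to compound 2 (0.15 log units; within the scatter), concerns a different exchange at the same place and lay within the scatter; no measured pair reproduces the present change, so there is nothing in the data that directly bears on it. The estimate for compound 3 therefore rests on compound 2, which gives 1700 nM, and is expected to move upward by a 2.4-fold higher number from compound 2 to compound 3 (0.37 log units; beyond the scatter). In this assay compound 3 is expected to fall near 4000 nM, within a range from 1500 nM to 12000 nM, and the measurement will show whether that expectation holds.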

Compound 3, solubility: 5700 nM
The estimate for compound 3 lay 1.4-fold (0.15 log units) below the measured number, and the stated range covers the measured number.
By their numbers in this assay, from the lowest: compounds 1 and 2 (each within the scatter of the next); then compound 3.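

For the compounds shown here, at this position, on an aromatic carbon opposite the ring nitrogen and ortho to a cyano group, the exchange of one aryl group for another can move the number in this assay beyond the scatter: the result is a 3.4-fold higher number from compound 2 to compound 3 (0.53 log units; beyond the scatter) and a 4.8-fold higher number from compound 1 to compound 3 (0.68 log units; beyond the scatter), whereas the only earlier step, a 1.4-fold higher number from compound 1 to compound 2 (0.15 log units; within the scatter), stayed within it. The 2-chlorophenyl and 4-hydroxyphenyl groups have the same heavy-atom count and each has one six-membered aromatic ring of carbon only, so the step comes without a change in that count, while the entering group brings 1 hydrogen-bond donor and 1 hydrogen-bond acceptor and its substituent stands at a different ring place. Nothing in the data shown gives a cause for this rise.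

The kind of substituent and its place on the ring change together in both steps, so the compounds shown cannot separate the two, and a 2-hydroxyphenyl or a 4-chlorophenyl group would be needed to pull them apart. On these data alone, whether an amine or a carboxylic acid on the same phenyl ring would give a number like that of compound 3 also remains open.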